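Shortening the Sulfonyl Substituent: Expected Solubility of Compound 4

A few compounds are considered here, and "the series" means these few. Any claim that something is new, unique, unknown or untested is made for them only; others in the source may bear on it.

Measured so far:
compound 1 `O=S(=O)(c1cccc(-c2ccc3nccc(-c4ccncc4)c3n2)c1)N1CCC(O)CC1`, 10000 nM
compound 2 `NCCNS(=O)(=O)c1cccc(Nc2ccc3nccc(-c4ccncc4)c3n2)c1`, 200000 nM
compound 3 `NS(=O)(=O)c1cccc(-c2ccc3nccc(-c4cn[nH]c4)c3n2)c1`, only a limit

In a physicochemical assay for solubility, read by HPLC, using the shake flask method, measured as kinetic solubility, with a stated time of 20 h, at pH 6.5, tested at 200 uM (on this read-out higher numbers stand for higher solubility and lower numbers for lower solubility), compound 1 gives 10000 nM, the lowest of the two numbers shown; compound 2 gives 200000 nM, a higher number beyond the scatter. For compound 3 this assay reports only a limit, < 5000 nM, as noted in the limit of < 5000 nM in this assay, at which 1 of the 3 values shown sits.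

Compound 4 `O=S(=O)(CCO)c1cccc(-c2ccc3nccc(-c4ccncc4)c3n2)c1` differs from compound 1 in one place: 2-hydroxyethyl in place of 4-hydroxypiperidin-1-yl on a sulfonyl sulfur. Among the compounds with values here, no measured pair shows this change, so the account is an expectation. Compound 4 is estimated at 15000 nM, within 4000 nM to 60000 nM. The step from compound 1 to compound 4 is expected to be a 1.5-fold higher number from compound 1 to compound 4 (0.18 log units; within the scatter), a small move toward higher solubility that need not exceed the scatter.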

Compound 4, solubility: 55000 nM
The estimate for compound 4 lay 3.7-fold (0.56 log units) below the measured number; the range from low to high includes it.
By their numbers in this assay, from the lowest: compound 1; then compound 4; then compound 2. At a limit, below all of these: compound 3.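

In this assay, 2-hydroxyethyl in place of 4-hydroxypiperidin-1-yl on a sulfonyl sulfur gives a 5.5-fold higher number from compound 1 to compound 4 (0.74 log units; beyond the scatter), the only step shown at this position. The group on this sulfur thus moves the read-out beyond the scatter, although the ring is lost while the counted donors and acceptors stay the same. Nothing measured here accounts for the step.

On these data alone, whether the loss of the ring or the shorter chain matters more remains open. So does how an amine, a carboxylic acid or a longer chain would read on this sulfur.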